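The source may report more compounds than this note shows. Statements on the series, on what has been measured and on what is new or still open speak of the compounds shown alone.

Compound 1 `C#Cc1cn([C@@H]2O[C@H](CO)[C@@H](O)[C@H]2O)c2ncnc(OC)c12` gives 380 nM in a functional assay on K562 cells (Homo sapiens), read by MTT assay, with a stated time of 72 h (on this read-out higher numbers stand for weaker inhibition and lower numbers for stronger inhibition), the highest of the two numbers measured there. Among the compounds with values here, compound 3 `C#Cc1cn([C@@H]2O[C@H](CO)[C@@H](O)[C@H]2O)c2ncnc(N(C)C)c12` gives 260 nM in this assay; the step of a 1.5-fold lower number from compound 1 to compound 3 (0.16 log units; within the scatter) is the only single change measured so far. Compound 2 `Nc1nc(N)c2c(-c3ccoc3)cn([C@@H]3O[C@H](CO)[C@@H](O)[C@H]3O)c2n1` reaches only > 20000 nM in this assay, which is the limit of > 20000 nM in this assay, at which 1 of the 3 values shown sits, rather than a number. Compound 4 `COc1ncnc2c1c(-c1ccsc1)cn2[C@@H]1O[C@H](CO)[C@@H](O)[C@H]1O` has not been measured; it differs from compound 1 by thiophen-3-yl in place of ethynyl on an aromatic carbon. Within the data shown here, no measured step shows this exchange, and the step from compound 1 to compound 3 concerns another part of the core, so it gives no guide. Compound 4 is therefore expected to land close by, the step of a 2.1-fold higher number from compound 1 to compound 4 (0.32 log units; beyond the scatter) being modest. The estimate for compound 4 is 800 nM, within 150 nM to 5000 nM.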

Compound 4, half-maximal inhibitory concentration: 3450 nM
Compound 4: the middle estimate sits 4.3-fold (0.63 log units) below what was measured; the measured number falls inside the stated range.
By their numbers in this assay, from the lowest: compounds 3 and 1 (each within the scatter of the next); then compound 4. At a limit, above all of these: compound 2.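

The aromatic carbon that bears ethynyl in compound 1 proves sensitive to what sits on it: thiophen-3-yl in place of ethynyl gives a 9.1-fold higher number from compound 1 to compound 4 (0.96 log units; beyond the scatter) and so weaker inhibition. Within the data shown here, the earlier single change, on another part of the core, stayed within the scatter, so this is the first step that clearly moves the number. Nothing measured here explains the size of this step. Going by these compounds, whether a methyl group, a nitrile or a phenyl ring on this carbon would keep the level of ethynyl or fall like thiophen-3-yl remains open.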